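The compounds below may be only part of what the source reports. "The series", "measured", "known", "first", "only" and "open" are said of these compounds alone.

Compound 1 `CCN1CCN(c2cc(C)c3cc(NC(=O)c4ccc(Cl)cc4)ccc3n2)CC1` belongs to a small set of three measured amides sharing one core. In a functional assay on MCF7 cells (Homo sapiens) for antiproliferative activity, read by MTT assay, with a stated time of 72 h (on this read-out higher numbers stand for weaker inhibition and lower numbers for stronger inhibition), compound 1 gives 1530 nM. Compound 2 `Cc1cc(N2CCN(C(C)C)CC2)nc2ccc(NC(=O)c3ccc(Cl)c(Cl)c3)cc12` gives 1710 nM in this assay, and compound 3 `Cc1cc(NCCN2CCCC2)nc2ccc(NC(=O)c3ccc(Cl)c(Cl)c3)cc12` gives 1280 nM; the three numbers lie within the scatter of one another, so compound 1 sits in the middle of a group that cannot be ordered on these data. Among the measured compounds shown here, the only single-point step among them, a 1.3-fold lower number from compound 2 to compound 3 (0.13 log units; within the scatter), concerns the amine part and not the aryl amide.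

Compound 4 `CCN1CCN(c2cc(C)c3cc(NC(=O)c4ccccc4)ccc3n2)CC1` is the analogue of compound 1 in which the aryl amide is changed: hydrogen in place of chloro on an aromatic carbon. For the measured compounds named here, no measured step bears directly on this change; compound 1 and compound 2 differ in the aryl amide as well as in the amine, and their values show no difference beyond the scatter. The step in this assay is therefore expected to be small, if anything toward a somewhat higher number, as a 1.6-fold higher number from compound 1 to compound 4 (0.21 log units; within the scatter). Compound 4 is estimated at 2500 nM, within a range from 1000 nM to 6000 nM.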

Compound 4, half-maximal inhibitory concentration: 14200 nM
Compound 4: middle estimate off by 5.7-fold (0.75 log units), on the low side, and the stated range ends below it.
By their numbers in this assay, from the lowest: compounds 3, 1 and 2 (each within the scatter of the next); then compound 4.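

In this assay, the chloro on the aromatic carbon para to a large group proves far from neutral: replacing this single heavy atom with hydrogen gives a 9.3-fold higher number from compound 1 to compound 4 (0.97 log units; beyond the scatter). Among the compounds shown here, this is the first single-point step at the aryl amide, and unlike the one step available earlier, which concerned the amine part and stayed within the scatter, it lies beyond the scatter, so the chloro of compound 1 is tied to a clear difference in this antiproliferative read-out, while the benzoyl amide of compound 4 separates from the group of compounds 1, 2 and 3. Nothing available explains why removing this chlorine has an effect of this size.

The compounds shown do not tell whether the chloro itself is specifically needed, since no compound carries fluoro, bromo, methyl, methoxy or trifluoromethyl in its place on the same core. For the compounds shown here, they also leave open whether the same change would have a similar size alongside the 4-isopropylpiperazin-1-yl or (2-(pyrrolidin-1-yl)ethyl)amino groups, as no such single-point pair appears here.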